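This account rests on a few compounds, and the source may have more. Where it says the series, first, only, none or still open, it means among the compounds named here.

Compound 2 `COc1ccc(Cc2ccc3cc(NC(=O)c4ccc(O)c(CC=C(C)C)c4)c(=O)oc3c2C)cc1OC` and compound 1 `COc1cccc(Cc2ccc3cc(NC(=O)c4ccc(O)c(CC=C(C)C)c4)c(=O)oc3c2C)c1` share one core and differ in a single place, (hydrogen in place of methoxy on an aromatic carbon). In a functional assay on MCF7 cells (Homo sapiens) for antiproliferative activity (a higher number here means a weaker inhibitor, a lower number a stronger inhibitor), compound 2 gives 13900 nM, and compound 1 gives 19700 nM; the step between them is a 1.4-fold higher number from compound 2 to compound 1 (0.15 log units; within the scatter). Compound 3 `COCOc1ccc(Cc2ccc3cc(NC(=O)c4ccc(OC(C)=O)c(CC=C(C)C)c4)c(=O)oc3c2C)cc1OC` carries a different core, and the difference between the two cores is not broken down here. In this assay compound 3 gives 14900 nM. Compound 4 `COCOc1ccc(Cc2ccc3cc(NC(=O)c4ccc(OC(C)=O)c(CC=C(C)C)c4)c(=O)oc3c2C)cc1` arises from compound 3 by the same kind of change, (hydrogen in place of methoxy on an aromatic carbon); around the place, the group that leaves is ortho to a methoxymethoxy group and meta to a large group, whereas in the earlier pair it was ortho to a methoxy group and para to a large group. Because the earlier step was a 1.4-fold higher number from compound 2 to compound 1 (0.15 log units; within the scatter), the expected step is a 1.3-fold higher number from compound 3 to compound 4 (0.11 log units; within the scatter). The estimated value for compound 4 is 19000 nM, with a range from 9000 nM to 40000 nM.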

Compound 4, half-maximal inhibitory concentration: 22700 nM
Beside the measured number, compound 4's estimate is 1.2-fold (0.08 log units) below it, within the range that was stated.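

In this assay, replacing the methoxy with hydrogen gives a 1.5-fold higher number from compound 3 to compound 4 (0.18 log units; within the scatter). Set beside the same replacement on the other core, the two steps agree: the same change on two cores in this assay, a 1.4-fold higher number (0.15 log units; within the scatter) from compound 2 to compound 1 and a 1.5-fold higher number (0.18 log units; within the scatter) from compound 3 to compound 4, 1.1-fold (0.03 log units) apart, within the scatter of two such steps. The change therefore reads alike on these two cores, but both steps lie within the scatter, so the pairs show no measurable effect of the methoxy on either core and give no rule for cores not shown here.

As far as these compounds go, it remains open whether another group in that place, such as an amine or a carboxylic acid, would give a step beyond the scatter. From the compounds shown here alone, all four values come from this assay, so how the change reads elsewhere also stays open.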